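The compounds below may be only part of what the source reports. "The series", "measured", "known", "first", "only" and "open" are said of these compounds alone.

Of the compounds shown here, three have been tested in a functional assay on NCI/ADR cells (Homo sapiens) for inhibition, read by sulforhodamine B assay, with a stated time of 48 h; a lower number here means a stronger inhibitor of growth, a higher number a weaker inhibitor of growth. Compound 1, `COc1ccc(/C=C/C2CC(=O)C=CO2)cc1OC`, and compound 2, `COc1cc(/C=C/C2CC(=O)C=CO2)cc(OC)c1OC`, share one core, while compound 3, `COc1ccc(/C=C/c2cc(=O)cco2)cc1`, is built on a different core. In this assay compound 1 gives 146 uM. In this assay compound 2 gives 223 uM. In this assay compound 3 gives 310 uM. The difference between the core of compound 1 and the core of compound 3 is not broken down here. Among these three, compound 3 stands at the highest number, but its gap to compound 2 is within the scatter, so no order between those two can be claimed.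

Compound 2 differs from compound 1 by methoxy in place of hydrogen on an aromatic carbon, and this change gave a 1.5-fold higher number from compound 1 to compound 2 (0.18 log units; within the scatter). The unmeasured compound 4, `COc1ccc(/C=C/c2cc(=O)cco2)cc1OC`, differs from compound 3 by methoxy in place of hydrogen on an aromatic carbon. This is the same kind of change, though not the same: around the place in compound 1 there is also a methoxy group in the meta position, which is absent around the place in compound 3.

Going by the values given here, only one earlier instance of this kind of change is available, and it stayed within the scatter, so the expectation for compound 4 rests on it alone. The step of a 1.2-fold higher number from compound 3 to compound 4 (0.09 log units; within the scatter) is expected to be small because a 1.5-fold higher number from compound 1 to compound 2 (0.18 log units; within the scatter) was small for the same kind of change. Compound 4 is therefore estimated at about 380 uM, most likely between 180 uM and 800 uM.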

Compound 4, concentration for growth inhibition (reported as GI): 408 uM
Beside the measured number, compound 4's estimate is 1.1-fold (0.03 log units) below it; low and high end bracket the measured number.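

In this assay, putting methoxy in place of hydrogen on an aromatic carbon gave a 1.3-fold higher number from compound 3 to compound 4 (0.12 log units; within the scatter), so on this second core the change again left the number about where it started. Set beside the earlier step, the same change looks alike on the two cores, since the two steps cannot be told apart: the same change on two cores in this assay, a 1.5-fold higher number (0.18 log units; within the scatter) from compound 1 to compound 2 and a 1.3-fold higher number (0.12 log units; within the scatter) from compound 3 to compound 4, 1.2-fold (0.06 log units) apart, within the scatter of two such steps. Going by these compounds alone, this shows only that the change did little on either core; neither step stands clear of the scatter, so the shared direction of the two steps cannot be read as a real trend, and two pairs of compounds say nothing about how the change would behave on any other core.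

On these data alone, every substituent on the aromatic ring in these compounds is a methoxy group, so it remains open whether a different group there, such as an amine, a carboxylic acid or a longer chain like butoxy, would move the number beyond the scatter. As far as these compounds go, it is also open whether the small size of this step holds in cells other than those used here, as all four compounds are compared in a single assay.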